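Swapping 3-methoxyphenyl for 2-fluorobenzyl on the amide nitrogen

The source may hold more compounds than are shown below. What is called first, only, known or untested is meant among the compounds shown, and "the series" means these compounds.

Three amides sharing one core have been measured in a functional assay on A549 cells (Homo sapiens) for inhibition, read by MTT assay, with a stated time of 48 h (a higher number here means a weaker inhibitor, a lower number a stronger inhibitor), so far. Compound 1 (`COc1ccc2c(=O)c(/C=C/C(=O)Nc3cccc(C)c3)coc2c1`) gives > 100000 nM there, and this is a limit of the assay, not a number. Compound 2 (`COc1ccc2c(=O)c(/C=C/C(=O)Nc3ccccc3Cl)coc2c1`) gives 29900 nM in this assay on the same core. Compound 3 (`COc1cccc(NC(=O)/C=C/c2coc3cc(OC)ccc3c2=O)c1`) gives 12800 nM and stands lowest of the set. The data show a 2.3-fold lower number from compound 2 to compound 3 (0.37 log units; beyond the scatter) as well as an at least 7.8-fold lower number from compound 1 to compound 3 (0.89 log units; beyond the scatter) against the limit. They also show an at least 3.3-fold lower number from compound 1 to compound 2 (0.52 log units; beyond the scatter) for the remaining pair.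

Compound 4 (`COc1ccc2c(=O)c(/C=C/C(=O)NCc3ccccc3F)coc2c1`) has not been measured. It carries 2-fluorobenzyl in place of 3-methoxyphenyl on an amide-type nitrogen. Among the compounds with values here, no measured step brings in a benzyl group, so the three steps at this nitrogen bear on the change only indirectly. They do show that exchanges there matter. Compound 3 gives 12800 nM, and each compound that lacks 3-methoxyphenyl sits higher. A modest rise is therefore expected, the estimated step being a 2.3-fold higher number from compound 3 to compound 4 (0.37 log units; beyond the scatter) in this assay with wide uncertainty. For compound 4 the estimate is 30000 nM (expected range 8000 nM to 100000 nM).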

Compound 4, half-maximal inhibitory concentration: > 100000 nM
Compound 4 ended at the assay's limit; the forecaster's own chance of this, stated with the estimate: 20%; middle value at least 3.3-fold (0.52 log units) from the limit.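

Compound 4 joins compound 1 at a limit of this assay, which is a limit and not a number: the limit of > 100000 nM in this assay, at which 2 of the 4 values shown sit.

On the amide-type nitrogen, the exchange of 3-methoxyphenyl for 2-fluorobenzyl gives an at least 7.8-fold higher number from compound 3 to compound 4 (0.89 log units; beyond the scatter), and the exchange of 2-chlorophenyl for the same group gives an at least 3.3-fold higher number from compound 2 to compound 4 (0.52 log units; beyond the scatter), while the step between compound 1 and compound 4 cannot be read, as both values are limits. Within the data shown here, until this result, the set held only substituted phenyl groups at this nitrogen, so compound 4 adds the first view of a benzyl group there, and that group does not reach the measured range of compound 2 and compound 3.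

The four compounds leave open whether the loss goes with the benzyl group itself or with its fluorine, a question that a 2-fluorophenyl group or a plain benzyl group on the same nitrogen would bear on. They also leave open whether a 3-methoxybenzyl group would stay at the limit, and how a longer chain between the nitrogen and the ring would read in this assay.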